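A few compounds are considered here, and "the series" means these few. Any claim that something is new, unique, unknown or untested is made for them only; others in the source may bear on it.

Compound 1 `O=C(Nc1ccc(F)cc1)N[C@H]1CC[C@H](Oc2ccc(F)cc2)CC1`: 20000 nM
Compound 2 `O=C(Nc1ccccc1Br)N[C@H]1CC[C@H](Oc2ccc(F)cc2)CC1`: 7700 nM
Compound 3 `O=C(Nc1cccc([N+](=O)[O-])c1)N[C@H]1CC[C@H](Oc2ccc(F)cc2)CC1`: 6700 nM

Of the compounds shown here, three sharing one core have been measured in a functional assay on CRL2813 cells (Homo sapiens) for cytotoxicity, read by sulforhodamine B assay, with a stated time of 5 days; a higher number here means a weaker inhibitor, a lower number a stronger inhibitor. Compound 1 gives 20000 nM, the highest of the three numbers. The nearest of the others is compound 2, which gives 7700 nM; the step is a 2.6-fold lower number from compound 1 to compound 2 (0.41 log units; beyond the scatter). Compound 3 gives 6700 nM, and the step of a 3.0-fold lower number from compound 1 to compound 3 (0.47 log units; beyond the scatter) is of similar size. Between the two lower numbers the step of a 1.1-fold lower number from compound 2 to compound 3 (0.06 log units; within the scatter) lies within the scatter, so nothing separates compound 2 from compound 3.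

Compound 4 `O=C(Nc1cccc(C(=O)O)c1)N[C@H]1CC[C@H](Oc2ccc(F)cc2)CC1` has not yet been measured in this assay. It differs from compound 1 in one place: 3-carboxyphenyl in place of 4-fluorophenyl on an amide-type nitrogen. Going by the values given here, the two steps already seen away from compound 1 both exchanged the 4-fluorophenyl for another substituted phenyl on the same amide-type nitrogen, and both lowered the number modestly; no measured step involves a 3-carboxyphenyl, so the closest guide is the change to 3-nitrophenyl in compound 3. On that basis compound 4 is expected to show a modest lowering of the number, an estimated step of a 1.7-fold lower number from compound 1 to compound 4 (0.22 log units; within the scatter). Compound 4 is therefore estimated at 12000 nM, with a range from 5000 nM to 30000 nM.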

Compound 4, half-maximal inhibitory concentration: > 20000 nM
Compound 4 was reported as a limit; the forecaster's own chance of this, stated with the estimate: 15%; middle value at least 1.6-fold (0.22 log units) away from the limit.
By their numbers in this assay, from the lowest: compounds 3 and 2 (each within the scatter of the next); then compound 1.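

In this assay compound 4 is reported only as a limit, > 20000 nM. Carboxy in place of nitro on an aromatic carbon gives an at least 2.9-fold higher number from compound 3 to compound 4 (0.47 log units; beyond the scatter), and 3-carboxyphenyl in place of 2-bromophenyl on the amide-type nitrogen gives an at least 2.5-fold higher number from compound 2 to compound 4 (0.41 log units; beyond the scatter), so the lower numbers of compound 2 and compound 3 do not extend to every substituted phenyl at this place, and the exchange of a nitro for a carboxy alone is enough to lose the lower number of compound 3. 3-carboxyphenyl in place of 4-fluorophenyl on the amide-type nitrogen gives a number no lower from compound 1 to compound 4 (the limit leaves the size open), a step whose size cannot be read. The value of compound 1 stands at the same figure as the limit, so the data show no lowering for compound 4 but cannot say how far its number lies from that of compound 1: the limit of > 20000 nM in this assay, at which 1 of the 4 values shown sits.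

From the compounds shown here alone, whether a methyl ester or a primary amide in place of the carboxy would return the number to the range of compound 2 and compound 3 stays open. So does how an amine on the same phenyl ring would read, and what the number of compound 4 is beyond its limit.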